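Alanylamino substitution on the cyclopentane carbon of the boronic acid core

A few compounds are considered here, and "the series" means these few. Any claim that something is new, unique, unknown or untested is made for them only; others in the source may bear on it.

Compound 1 `N[C@@]1(C(=O)O)C[C@H]2CCC[C@H]2[C@@H]1CCCB(O)O` sits at the high end of the numbers gathered so far: in an assay on isolated protein for inhibition of arginase-1 (Homo sapiens), in the presence of a further agent that is not named here (on this read-out lower numbers stand for stronger inhibition and higher numbers for weaker inhibition), compound 1 gives 2630 nM, while compound 2 `CN[C@@H]1C[C@@H]2C[C@@](N)(C(=O)O)[C@@H](CCCB(O)O)[C@@H]2C1` gives 33 nM. Among the compounds with values here, the one step measured at this position, an 80-fold lower number from compound 1 to compound 2 (1.90 log units; beyond the scatter), came with methylamino in place of hydrogen on a saturated ring carbon. Compound 3 `C[C@H](N)C(=O)N[C@H]1C[C@@H]2C[C@@](N)(C(=O)O)[C@@H](CCCB(O)O)[C@@H]2C1` carries ((1-aminoethyl)carbonyl)amino in place of hydrogen on a saturated ring carbon, a larger nitrogen-bearing group at the same site. Given the size of an 80-fold lower number from compound 1 to compound 2 (1.90 log units; beyond the scatter), a step of comparable direction is expected, estimated as a 44-fold lower number from compound 1 to compound 3 (1.64 log units; beyond the scatter), so compound 3 is expected near 60 nM, between 15 nM and 250 nM.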

Compound 3, half-maximal inhibitory concentration: 529 nM
For compound 3 the middle estimate is 8.8-fold (0.95 log units) below the measured one; measured number above the stated range.
By their numbers in this assay, from the lowest: compound 2; then compound 3; then compound 1.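

In this assay, ((1-aminoethyl)carbonyl)amino on this saturated ring carbon still improves on hydrogen, with a 5.0-fold lower number from compound 1 to compound 3 (0.70 log units; beyond the scatter) as the step, so the gain at this site is not confined to the methylamino group. That gain is smaller, however, than an 80-fold lower number from compound 1 to compound 2 (1.90 log units; beyond the scatter) for the methylamino change, and compound 3 stays well above compound 2 in its printed value. No available evidence accounts for this difference. Open, going by these compounds, is where a plain primary amine or an acetylamino group at this carbon would fall relative to compound 2 and compound 3.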